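Swapping a Bromophenyl for a Methoxyphenyl on a Chalcone

The source may report more compounds than this note shows. Statements on the series, on what has been measured and on what is new or still open speak of the compounds shown alone.

Measured compounds:
compound 1 `COc1cc(/C=C/C(=O)c2ccc(N)c(-c3ccc(F)cc3)c2)cc(Br)c1O` in an assay on A549 cells for inhibition of transcription factor p65 (Homo sapiens), read by fluorescence, with a stated time of 2 h; a lower number here means a stronger inhibitor, a higher number a weaker inhibitor: > 50000 nM
compound 2 `O=C(/C=C/c1ccc(Br)cc1)c1cccc(-c2cccc(F)c2)c1` in this assay : > 50000 nM

Compound 2 does not stand at a number at all: in this assay the value for compound 2 is a limit, the highest concentration tested, with no inhibition strong enough to give a reading. The same holds for compound 1, so the whole picture so far is the limit of > 50000 nM in this assay, at which 2 of the 2 values shown sit. Neither value therefore says how weak each compound really is; both could lie anywhere beyond that edge.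

Compound 3 `COc1ccccc1/C=C/C(=O)c1cccc(-c2cccc(F)c2)c1` has not yet been measured in this assay. It differs from compound 2 in one place: 2-methoxyphenyl in place of 4-bromophenyl on a double-bonded chain carbon bound to a double-bonded chain carbon. Within the data shown here, no pair of measured compounds shows what such a swap does, so the expected step has to be guessed rather than read off. With compound 2 already at the limit, the expectation is that the change from compound 2 to compound 3 is a number no higher from compound 2 to compound 3 (the limit leaves the size open), nothing beyond the scatter. Compound 3 is therefore expected to give about 50000 nM, with a likely range from 20000 nM to 120000 nM, and most probably once more only a limit.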

Compound 3, half-maximal inhibitory concentration: 35300 nM
Beside the measured number, compound 3's estimate is 1.4-fold (0.15 log units) above it, within the range that was stated.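

Among these compounds, compound 3 is the first compound here to give a number rather than a limit in this assay, so this place on the chain is one where a change of aryl group can move the result into the measurable range. Replacing 4-bromophenyl with 2-methoxyphenyl gives an at least 1.4-fold lower number from compound 2 to compound 3 (0.15 log units; that floor lies within the scatter). That figure is only a floor, and the true size of the step stays unknown, since compound 3 is the only compound with a number and the others remain limits: the limit of > 50000 nM in this assay, at which 2 of the 3 values shown sit.

The swap changes both the substituent and its place on the ring, and the compounds shown cannot separate the two. Going by these compounds, how 4-methoxyphenyl or 2-bromophenyl would read at this place on the chain remains open, as does whether a ring carrying an amine would read any differently.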